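A dichlorophenyl swap at the limit of the cytotoxicity read-out

A few compounds are considered here, and "the series" means these few. Any claim that something is new, unique, unknown or untested is made for them only; others in the source may bear on it.

In an ADME assay on MDBK cells (Bos taurus) for cytotoxicity (a higher number here means that more compound is tolerated, a lower number that less compound is tolerated), compound 3 `N#Cc1ccc(Cn2ccc3nc(-c4ccccc4)nc-3c2)cc1` gives > 100000 nM, which is a limit and not a number. Compound 1 `COc1ccccc1Cn1ccc2nc(-c3ccccc3)nc-2c1` gives > 100000 nM, which is also a limit. Compound 2 `Brc1ccccc1Cn1ccc2nc(-c3ccccc3)nc-2c1` gives > 100000 nM, again a limit. Within the data shown here, the whole series so far therefore comes down to the limit of > 100000 nM in this assay, at which 3 of the 3 values shown sit, and compound 3 has no readable rank among its neighbours.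

Compound 4 `Clc1ccc(Cn2ccc3nc(-c4ccccc4)nc-3c2)cc1Cl` has 3,4-dichlorophenyl in place of 4-cyanophenyl on a saturated chain carbon bound to an aromatic nitrogen. The closest precedents change the group at that same place, namely a step that the two limits leave unreadable from compound 1 to compound 3 and a step that the two limits leave unreadable from compound 2 to compound 3. The remaining comparison is a step that the two limits leave unreadable from compound 1 to compound 2. None of the three has a readable size, so they offer no measured effect to carry over, only the observation that three different groups all left the read-out at its limit. On that basis, the expected change is a number no higher from compound 3 to compound 4 (the limit leaves the size open), with nothing beyond the usual scatter anticipated in either direction. A reading at the same limit is the likeliest outcome. For compound 4 the estimated value in this assay is 100000 nM, with an expected range from 40000 nM to 200000 nM.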

Compound 4, half-maximal cytotoxic concentration: 71000 nM
For compound 4 the middle estimate is 1.4-fold (0.15 log units) above the measured one, within the range that was stated.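

Compound 4, at 71000 nM in this assay, is the only compound shown that gives a number. This shows that a change on the saturated chain carbon bound to an aromatic nitrogen can bring the read-out off the limit: the limit of > 100000 nM in this assay, at which 3 of the 4 values shown sit. Swapping in 3,4-dichlorophenyl gives an at least 1.4-fold lower number from compound 3 to compound 4 (0.14 log units; that floor lies within the scatter), while the comparison with the 2-bromophenyl group gives an at least 1.4-fold lower number from compound 2 to compound 4 (0.14 log units; that floor lies within the scatter) and the comparison with the 2-methoxyphenyl group gives an at least 1.4-fold lower number from compound 1 to compound 4 (0.14 log units; that floor lies within the scatter). From the compounds shown here alone, each of these is only a floor that lies within the scatter, so the true size of the change stays unknown and the result does not establish that compound 4 is tolerated any less than its neighbours.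

Going by these compounds, the steps among compound 1, compound 2 and compound 3 cannot be read, so any difference among those three groups remains open. On these data alone, it is also open whether a phenyl ring with a single chlorine would give a number at this place, and how a phenyl ring carrying an amine or a carboxylic acid would read.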